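The source may hold more compounds than are shown below. What is called first, only, known or untested is meant among the compounds shown, and "the series" means these compounds.

Working notes on the series. Two compounds carry numbers in a functional assay on MCF7 cells (Homo sapiens) for inhibition, read by sulforhodamine B assay, with a stated time of 24 h; a higher number here means a weaker inhibitor, a lower number a stronger inhibitor. Compound 1 `O=c1[nH]cnc2c1c(-c1ccccc1)cn2-c1ccc(S(=O)(=O)Nc2ccccn2)cc1` gives 5320 nM in this assay. Compound 2 `N#Cc1c(-c2ccccc2)cn(-c2ccc(S(=O)(=O)Nc3nccs3)cc2)c1N1C(=O)CCC1=O` gives 6710 nM in this assay. Compound 1 holds the lowest of the two numbers, yet compound 2 sits within the scatter of it, so the pair cannot be separated. For the measured compounds named here, no step between two measured compounds that differ in one place exists in this set, and nothing measured speaks directly to the change below.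

Compound 3 `Cc1nc2c(c(-c3ccccc3)cn2-c2ccc(S(=O)(=O)Nc3ccccn3)cc2)c(=O)[nH]1` has not yet been measured in this assay. It differs from compound 1 by methyl in place of hydrogen on an aromatic carbon of the shared core. Going by the values given here, with no comparable step measured, the change is expected to bring no movement beyond the scatter in this assay, and the estimated step is a 1.1-fold lower number from compound 1 to compound 3 (0.03 log units; within the scatter). Compound 3 is therefore estimated at 5000 nM in this assay, with a range from 2000 nM to 13000 nM.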

Compound 3, half-maximal inhibitory concentration: 5100 nM
Beside the measured number, compound 3's estimate is 1.0-fold (0.01 log units) below it; the measured number falls inside the stated range.
By their numbers in this assay, from the lowest: compounds 3, 1 and 2 (each within the scatter of the next).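

Methyl in place of hydrogen on an aromatic carbon, between two ring nitrogen atoms, gives the only one-place step in the series: in this assay it is a 1.0-fold lower number from compound 1 to compound 3 (0.02 log units; within the scatter). This place on the shared core therefore takes a methyl with no movement beyond the scatter, something compounds 1 and 2 could not show, as they differ in more than one place. No supporting data accompany this result to account for it.

Going by these compounds, whether the same place stays flat for groups other than methyl remains open, for instance an ethyl, an amine or a carboxylic acid. A single step also leaves open whether methyl here would read the same with a different group on the sulfonamide nitrogen.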